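The source may report more compounds than this note shows. Statements on the series, on what has been measured and on what is new or still open speak of the compounds shown alone.

Measured compounds in an assay on isolated protein for inhibition of protein kinase C zeta type (Homo sapiens), with a stated time of 4 min, tested at 62.5 uM; a lower number here means less inhibition, a higher number more inhibition at the concentration tested (going by the name of the read-out):

- compound 1, `CC(C)(C)C1=NN(c2ccc(Cl)cc2)C(c2ccc(F)cc2)C1`, gives 0%
- compound 2, `CC(C)(C)C1=NN(c2ccc(Cl)cc2)C(c2ccc(Br)cc2)C1`, gives 39%
- compound 3, `CC(C)(C)C1=NN(c2ccc(Cl)cc2)C(c2ccc(C#N)cc2)C1`, gives 20.7%

Compound 3 stands second highest of the three: it lies a number 18.3 percentage points lower from compound 2 to compound 3 (beyond the scatter) and a number 20.7 percentage points higher from compound 1 to compound 3 (beyond the scatter), both steps beyond the scatter.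

Compound 4, `CC(C)(C)C1=NN(c2ccc(Cl)cc2)C(c2ccc([N+](=O)[O-])cc2)C1`, differs from compound 3 in one place: nitro in place of cyano on an aromatic carbon. Among the compounds with values here, two measured steps bear on this position. The change from fluoro to bromo gave a number 39 percentage points higher from compound 1 to compound 2 (beyond the scatter), and the change from fluoro to cyano gave a number 20.7 percentage points higher from compound 1 to compound 3 (beyond the scatter), so substitution at this aromatic carbon moves the read-out by a modest to large amount, with the group's identity deciding the size. Nitro has not been tried anywhere in the series, so its direction relative to cyano is open; the step is expected to be no larger than the cyano-to-bromo step, a number 18.3 percentage points lower from compound 2 to compound 3 (beyond the scatter), in either direction.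

Compound 4 is therefore estimated at 27%, with a range of 5% to 50%, meaning an expected step of a number 6.3 percentage points higher from compound 3 to compound 4 (within the scatter), which may well fall within the scatter.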

Compound 4, a percentage reported as inhibition, at one concentration (the size of the read-out at that concentration, not a potency): 0%
For compound 4 the middle estimate is 27 percentage points above the measured one, outside the stated range (below it).
By their numbers in this assay, from the lowest: compounds 1 and 4 (each within the scatter of the next); then compound 3; then compound 2.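

In this assay the nitro group sides with fluoro rather than with bromo or cyano at this aromatic carbon, with no change at the digits printed from compound 1 to compound 4 (within the scatter). Against the other two groups the swap is clear: a number 20.7 percentage points lower from compound 3 to compound 4 (beyond the scatter), and a number 39 percentage points lower from compound 2 to compound 4 (beyond the scatter). The rise seen earlier on replacing fluoro therefore does not extend to every group, with nitro the exception among the compounds shown, and nothing at hand bears on a cause for this split.

From the compounds shown here alone, whether an amine, a methoxy group or a carboxylic acid at this aromatic carbon would side with compound 1 and compound 4 or with compound 2 and compound 3 remains open. Also open is whether the same split among these groups would hold with a change elsewhere on the shared core.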